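A 2-chlorobenzyl swap on the shared core

This account rests on a few compounds, and the source may have more. Where it says the series, first, only, none or still open, it means among the compounds named here.

In an ADME assay on HeLa cells (Homo sapiens) for cytotoxicity, read by MTT assay (a higher number here means a weaker inhibitor, a lower number a stronger inhibitor), compound 1 `COc1ccc(C[C@H]2COC(=O)[C@@H]2Cc2ccc(OCc3cn(-c4ccc(Br)cc4)nn3)c(OC)c2)cc1OC` gives 128000 nM and compound 2 `COc1ccc(C[C@H]2COC(=O)[C@@H]2Cc2ccc(OCc3cn(Cc4ccc(F)cc4)nn3)c(OC)c2)cc1OC` gives 198000 nM, so compound 2 stands level with compound 1 within the scatter. Compound 3 `COc1ccc(C[C@H]2COC(=O)[C@@H]2Cc2ccc(OCc3cn(Cc4ccccc4Cl)nn3)c(OC)c2)cc1OC` carries 2-chlorophenyl in place of 4-fluorophenyl on a saturated chain carbon bound to an aromatic nitrogen. Within the data shown here, the only measured step that bears on this change, a 1.5-fold higher number from compound 1 to compound 2 (0.19 log units; within the scatter), put 4-fluorobenzyl in place of 4-bromophenyl on an aromatic nitrogen and stayed within the scatter. The expected step is a 1.2-fold lower number from compound 2 to compound 3 (0.09 log units; within the scatter), and none beyond the scatter is expected in this assay. For compound 3 the estimated value is 160000 nM, with an expected range of 85000 nM to 300000 nM.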

Compound 3, half-maximal inhibitory concentration: 84500 nM
The estimate for compound 3 lay 1.9-fold (0.28 log units) above the measured number; the whole stated range lies above it.
By their numbers in this assay, from the lowest: compounds 3, 1 and 2 (each within the scatter of the next, the first and the last beyond it).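

In this assay, the change from 4-fluorobenzyl to 2-chlorobenzyl gave a 2.3-fold lower number from compound 2 to compound 3 (0.37 log units; beyond the scatter), a modest step but the first at this position to pass beyond the scatter. The 2-chlorobenzyl group set against 4-bromophenyl on the aromatic nitrogen gave a 1.5-fold lower number from compound 1 to compound 3 (0.18 log units; within the scatter), which leaves compound 3 level with compound 1. Nothing available explains the step from compound 2 to compound 3.

The compounds shown leave open how a plain benzyl group or a carboxylic acid would read at this place, on a saturated chain carbon bound to an aromatic nitrogen.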